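Shortening a branched chain on the shared core

A few compounds are considered here, and "the series" means these few. Any claim that something is new, unique, unknown or untested is made for them only; others in the source may bear on it.

Compounds measured in a functional assay on ileum for inhibition of histamine H1 receptor (Cavia porcellus); on this read-out higher numbers stand for weaker inhibition and lower numbers for stronger inhibition:
compound 1 `CCCCCCn1c(N2CCN(C)CC2)nc2ccccc21`: 26 nM
compound 2 `CN1CCN(c2nc3ccccc3[nH]2)CC1`: > 3000 nM
compound 3 `CC(C)CCn1c(N2CCN(C)CC2)nc2ccccc21`: 1400 nM

Within the data shown here, compound 3 gives the highest of the two numbers known in this assay. Its nearest neighbour is compound 1, and the step of a 54-fold higher number from compound 1 to compound 3 (1.73 log units; beyond the scatter) is large. Compound 2 reaches only a limit of the assay (the limit of > 3000 nM in this assay, at which 1 of the 3 values shown sits), so it is not a number and ranks no further. The step of an at least 110-fold higher number from compound 1 to compound 2 (2.06 log units; beyond the scatter) shows that taking the chain away altogether costs much, while the step of an at least 2.1-fold lower number from compound 2 to compound 3 (0.33 log units; beyond the scatter) shows that the isopentyl chain restores only part of it.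

Compound 4 (`CCCn1c(N2CCN(C)CC2)nc2ccccc21`) is not yet measured. It differs from compound 3 as methyl in place of isopropyl on a saturated chain carbon, two bonds along the chain from an aromatic nitrogen, which on the whole chain reads as isopentyl to propyl. The measured steps pull in two directions: the step from compound 1 to compound 3 suggests that branching two bonds along the chain from the aromatic nitrogen is costly, so removing it may lower the number, whereas the steps from compound 1 to compound 2 and from compound 2 to compound 3 suggest that a shorter chain tends to raise it. The expected outcome is therefore a modest step of a 3.5-fold lower number from compound 3 to compound 4 (0.54 log units; beyond the scatter), with wide uncertainty. Compound 4 is estimated at 400 nM, between 60 nM and 2500 nM.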

Compound 4, half-maximal inhibitory concentration: 380 nM
Estimate against measurement, compound 4: 1.1-fold (0.02 log units) above, within the range that was stated.
By their numbers in this assay, from the lowest: compound 1; then compound 4; then compound 3. At a limit, above all of these: compound 2.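

In this assay, removing the branch from the isopentyl chain to leave propyl gives a 3.7-fold lower number from compound 3 to compound 4 (0.57 log units; beyond the scatter), so on this position the longer branched chain gives a higher number than the shorter straight one. Shortening the hexyl chain to propyl still raises the number, a 15-fold higher number from compound 1 to compound 4 (1.16 log units; beyond the scatter), so chain length alone does not order these groups, and the isopentyl chain goes against any simple rise with shortening. The step of an at least 7.8-fold lower number from compound 2 to compound 4 (0.89 log units; beyond the scatter) is only a bound, since its starting compound stands at a limit and not at a number: the limit of > 3000 nM in this assay, at which 1 of the 4 values shown sits.

The compounds shown hold only one branched chain, so they leave open how the number moves through straight butyl and pentyl chains, and whether a branch placed elsewhere on the chain would cost as much. They also do not tell whether a chain longer than hexyl, or a chain ending in an amine or a carboxylic acid, would lower the number further or raise it.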